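The source may hold more compounds than are shown below. What is called first, only, known or untested is meant among the compounds shown, and "the series" means these compounds.

Compound 3 `Nc1cc(Cc2ccn(-c3ccccn3)n2)c2nn[nH]c2n1` stands highest of the three numbers in an assay on cells for inhibition of thyroid peroxidase (Homo sapiens), with stated times of 10 min and 15 min (on this read-out lower numbers stand for stronger inhibition and higher numbers for weaker inhibition), at 2000 nM; compound 1 `Nc1cc(Cc2ccn(-c3ccc(F)cc3)n2)c2nn[nH]c2n1` gives 700 nM and compound 2 `Nc1cc(Cc2ccn(-c3cccc(-c4ccccc4)c3)n2)c2nn[nH]c2n1` gives 710 nM, the two of which lie within the scatter of each other. Compound 4 `Nc1cc(Cc2ccn(-c3ccccc3)n2)c2nn[nH]c2n1` differs from compound 3 by phenyl in place of pyridin-2-yl on an aromatic nitrogen. For the measured compounds named here, the one measured step that bears on this change is a 2.9-fold higher number from compound 1 to compound 3 (0.46 log units; beyond the scatter), which ran in the opposite direction, putting pyridin-2-yl on the aromatic nitrogen in place of a carbon-only ring. Reversing it, a modest lowering of the number is expected for compound 4 relative to compound 3 in this assay, estimated as a 2.5-fold lower number from compound 3 to compound 4 (0.40 log units; beyond the scatter). Compound 4 is therefore estimated at 800 nM, with a range from 350 nM to 1800 nM.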

Compound 4, half-maximal inhibitory concentration: 640 nM
Beside the measured number, compound 4's estimate is 1.3-fold (0.10 log units) above it; measured number inside the range.
By their numbers in this assay, from the lowest: compounds 4, 1 and 2 (each within the scatter of the next); then compound 3.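

Direct comparison in this assay now isolates the ring nitrogen: a 3.1-fold lower number from compound 3 to compound 4 (0.49 log units; beyond the scatter), so the weaker result of compound 3 is not specific to the comparison with 4-fluorophenyl. Removing either substituent from the carbon-only ring leaves the number within the scatter: a 1.1-fold lower number from compound 1 to compound 4 (0.04 log units; within the scatter), and a 1.1-fold lower number from compound 2 to compound 4 (0.05 log units; within the scatter). No measurement shown accounts for the gap between pyridin-2-yl and phenyl.

Open, on these data alone, is whether an amine or a carboxylic acid on the phenyl ring would shift the number. Also open, as far as these compounds go, is whether pyrimidin-2-yl would track with pyridin-2-yl.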